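The compounds below may be only part of what the source reports. "The series", "measured", "known", "first", "only" and "open" are said of these compounds alone.

Compound 1, `COc1ccc(-c2cc(/C=C/C(=O)c3ccc(N)cc3)[nH]n2)cc1`: 39800 nM
Compound 2, `COc1cc(-c2cc(/C=C/C(=O)c3ccc(N)cc3)[nH]n2)cc(OC)c1OC`: 51600 nM

Of the compounds shown here, two have so far been tested in a functional assay on TK-10 cells (Homo sapiens) for inhibition, read by sulforhodamine B assay, with a stated time of 48 h; on this read-out higher numbers stand for lower toxicity in this test and lower numbers for higher toxicity in this test. Compound 1 gives 39800 nM, and compound 2 gives 51600 nM. These two numbers lie within the scatter of each other, so nothing separates the two compounds in this assay, and compound 2 has no measured neighbour that differs from it in a single place. Compound 3, `COc1cc(-c2cc(/C=C/C(=O)c3ccc(Cl)c(Cl)c3)[nH]n2)cc(OC)c1OC`, keeps the core of compound 2 and differs in one group: 3,4-dichlorophenyl in place of 4-aminophenyl on a carbonyl carbon. Within the data shown here, no measured pair shows how this kind of swap moves the number in this assay, so the expectation leans on the narrow spread of the two known values, with room for a moderate shift towards a lower number. The step is estimated at a 1.7-fold lower number from compound 2 to compound 3 (0.24 log units; within the scatter). For compound 3 the expected value in this assay is 30000 nM, within a range from 10000 nM to 90000 nM.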

Compound 3, concentration lethal to 50% of the cells: > 100000 nM
Compound 3 ended at the assay's limit; the forecaster's own chance of this, stated with the estimate: 5%; middle value at least 3.3-fold (0.52 log units) from the limit.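

In this assay compound 3 gives > 100000 nM as its reading, and this is a limit of the assay, not a number. From the compounds shown here alone, putting 3,4-dichlorophenyl in place of 4-aminophenyl on the carbonyl carbon gives an at least 1.9-fold higher number from compound 2 to compound 3 (0.28 log units; that floor lies within the scatter) and so shows no sign of higher toxicity in this test, although the true size of the step remains unknown. With the shared core kept, the amino group of 4-aminophenyl is therefore not required for a high number here.

Going by these compounds, how far the number of compound 3 lies past the limit stays open. Also open, on these data alone, is whether a plain phenyl, a 4-hydroxyphenyl or a 4-carboxyphenyl group on the same carbonyl carbon would give a reading that can be measured.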